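This account rests on a few compounds, and the source may have more. Where it says the series, first, only, none or still open, it means among the compounds named here.

In a functional assay on HepG2 cells (Homo sapiens) for inhibition, read by MTT assay, with a stated time of 72 h (on this read-out higher numbers stand for weaker inhibition and lower numbers for stronger inhibition), compound 1 `Nc1nc2cc(-c3nn(CCCCCCCCCC(=O)NO)c4ncnc(N)c34)ccc2o1` gives 28600 nM and compound 3 `Nc1nc2cc(-c3nn(CCCCCCCCC(=O)NO)c4ncnc(N)c34)ccc2o1` gives 2610 nM on the same scale. Compound 2 `Nc1nc2cc(-c3nn(CCCCC(=O)NO)c4ncnc(N)c34)ccc2o1` gives 2100 nM and stands level with compound 3 (a 1.2-fold higher number from compound 2 to compound 3 (0.09 log units; within the scatter)). The large steps in this small set are a 14-fold lower number from compound 1 to compound 2 (1.13 log units; beyond the scatter) and an 11-fold lower number from compound 1 to compound 3 (1.04 log units; beyond the scatter) in the same direction.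

Compound 4 `Nc1nc2cc(-c3nn(CC(=O)NO)c4ncnc(N)c34)ccc2o1` carries hydroxycarbamoyl in place of 3-(hydroxycarbamoyl)propyl on a saturated chain carbon bound to an aromatic nitrogen, compared with compound 2 (hydroxycarbamoyl in place of 3-(hydroxycarbamoyl)propyl on a saturated chain carbon bound to an aromatic nitrogen). Going by the values given here, no measured step covers a chain cut back this far. Compound 3 offers a guide with a change that stayed within the scatter (a 1.2-fold higher number from compound 2 to compound 3 (0.09 log units; within the scatter)), while compound 1 shows through a 14-fold lower number from compound 1 to compound 2 (1.13 log units; beyond the scatter) that chain length can matter in this series.

A modest rise, well short of those large steps, is therefore expected in this assay and is held loosely. The estimated step is a 2.4-fold higher number from compound 2 to compound 4 (0.38 log units; beyond the scatter) on this scale. Compound 4 is expected at about 5000 nM within an estimated range of 1200 nM to 20000 nM in this read-out.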

Compound 4, half-maximal inhibitory concentration: > 150000 nM
Compound 4: a limit, no number; the forecaster's own chance of this, stated with the estimate: 5%; at least 30-fold (1.47 log units) between middle value and limit.
By their numbers in this assay, from the lowest: compounds 2 and 3 (each within the scatter of the next); then compound 1. At a limit, above all of these: compound 4.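

Cutting the 4-(hydroxycarbamoyl)butyl chain of compound 2 back to the (hydroxycarbamoyl)methyl of compound 4, on a saturated chain carbon bound to an aromatic nitrogen, gives an at least 71-fold higher number from compound 2 to compound 4 (1.85 log units; beyond the scatter) in this assay. The earlier compounds shown here showed a large loss only on lengthening, with compound 1 set apart from the level pair of compound 2 and compound 3, whereas this step shows that a shorter chain can also cost a large loss. The reading for compound 4 is a limit and not a number: the limit of > 150000 nM in this assay, at which 1 of the 4 values shown sits.

As far as these compounds go, it remains open how a chain shorter than the 4-(hydroxycarbamoyl)butyl of compound 2 but longer than the (hydroxycarbamoyl)methyl of compound 4 would read in this assay. Also open, from the compounds shown here alone, is whether a carboxylic acid in place of the hydroxycarbamoyl end would keep a number like that of compound 2 2100 nM.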